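The source may hold more compounds than are shown below. What is called first, only, known or untested is meant among the compounds shown, and "the series" means these compounds.

In a functional assay on HT-29 cells (Homo sapiens) for antiproliferative activity, read by sulforhodamine B assay, with a stated time of 48 h (on this read-out lower numbers stand for stronger inhibition and higher numbers for weaker inhibition), compound 1 `O=C1NCCN1c1ccc(S(=O)(=O)Nc2ccccc2)cc1` gives 280 nM, compound 2 `O=C1NCCN1c1ccc(S(=O)(=O)Nc2ccc(F)c(F)c2)cc1` gives 350 nM and compound 3 `O=C1NCCN1c1ccc(S(=O)(=O)Nc2cccc(Br)c2)cc1` gives 77 nM, the lowest of the three numbers. Compound 4 `Cc1cc(C)cc(NS(=O)(=O)c2ccc(N3CCNC3=O)cc2)c1` is still unmeasured. It carries 3,5-dimethylphenyl in place of 3-bromophenyl on a sulfonamide nitrogen.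

Among the measured compounds shown here, three measured steps bear on this change. Bromo in place of hydrogen gave a 3.6-fold lower number from compound 1 to compound 3 (0.56 log units; beyond the scatter), and 3-bromophenyl in place of 3,4-difluorophenyl gave a 4.5-fold lower number from compound 2 to compound 3 (0.66 log units; beyond the scatter). Substitution alone does not lower the number, since compound 2 goes against that pattern with a 1.3-fold higher number from compound 1 to compound 2 (0.10 log units; within the scatter). For the measured compounds named here, no measured compound carries a methyl group, so the size of the step rests on indirect evidence.

Compound 4 loses the bromo, so part of the modest gain seen in a 3.6-fold lower number from compound 1 to compound 3 (0.56 log units; beyond the scatter) is expected to be given back, and a small rise is expected in this assay. The expected step is a 1.9-fold higher number from compound 3 to compound 4 (0.29 log units; within the scatter). For compound 4 the estimated value is 150 nM, with an expected range of 55 nM to 400 nM.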

Compound 4, half-maximal inhibitory concentration: 82 nM
The estimate for compound 4 lay 1.8-fold (0.26 log units) above the measured number; measured number inside the range.
By their numbers in this assay, from the lowest: compounds 3 and 4 (each within the scatter of the next); then compounds 1 and 2 (each within the scatter of the next).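

In this assay, 3,5-dimethylphenyl in place of 3-bromophenyl on the sulfonamide nitrogen gives a 1.1-fold higher number from compound 3 to compound 4 (0.03 log units; within the scatter), so among the compounds shown a low number at this position does not depend on bromo. The carbon-only 3,5-dimethylphenyl keeps the distance from both other groups, with a 3.4-fold lower number from compound 1 to compound 4 (0.53 log units; beyond the scatter) and a 4.3-fold lower number from compound 2 to compound 4 (0.63 log units; beyond the scatter); compounds 3 and 4 thus share a lower level that substitution alone does not give, as compound 2 goes against that pattern. No measured evidence accounts for this shared level.

Open, going by these compounds, is whether a single methyl, a methoxy group, an amine or a carboxylic acid on this phenyl ring would fall with compounds 3 and 4 or with compounds 1 and 2. Also open, on these data alone, is how a longer chain on the shared core would affect these numbers.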